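Butoxy to ethyl on the benzylidene series

The source may report more compounds than this note shows. Statements on the series, on what has been measured and on what is new or still open speak of the compounds shown alone.

The series is measured in a functional assay on MCF7 cells (Homo sapiens) for antiproliferative activity, read by sulforhodamine B assay, with a stated time of 72 h; on this read-out higher numbers stand for weaker inhibition and lower numbers for stronger inhibition. Going by the values given here, compound 1 `O=C1NC(=O)/C(=C\c2ccc(-c3ccc(Br)cc3)o2)S1` gives 47300 nM in this assay, a weak result that is the only number available. Compound 2 `CCCCOc1ccc(/C=C2\SC(=O)NC2=O)cc1` gives "not determined" (no result reported) in this assay, so it stands nowhere on the numbers shown and no anchor exists for the step to compound 3 `CCc1ccc(/C=C2\SC(=O)NC2=O)cc1`. The change from compound 2 to compound 3 is ethyl in place of butoxy on an aromatic carbon. With no measured pair of this kind in the series, the expected step cannot be sized from data; the change is a loss of the single hydrogen-bond acceptor and a shorter group, and no direction beyond the scatter is expected on that basis alone. Given that compound 1 sits at the weak end, compound 3 is estimated at 60000 nM in this assay, expected to fall between 15000 nM and 200000 nM, with a fair chance that only a limit is reported.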

Compound 3, half-maximal inhibitory concentration: > 100000 nM
Compound 3: only a limit was reported; the forecaster's own chance of this, stated with the estimate: 40%; middle value at least 1.6-fold (0.22 log units) from the limit.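

In this assay compound 3 gives > 100000 nM, which is a limit and not a number. Going by these compounds alone, compound 2 has no single number there, so no step from compound 2 to compound 3 can be read. On these data alone, how butoxy and ethyl compare on the shared core remains open.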